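The source may report more compounds than this note shows. Statements on the series, on what has been measured and on what is new or still open speak of the compounds shown alone.

Measured in a functional assay on NCI-H460 cells (Homo sapiens) for inhibition, with a stated time of 72 h; on this read-out higher numbers stand for weaker inhibition and lower numbers for stronger inhibition:
- compound 1 `COc1ccc(S(=O)(=O)N2CCc3cccc(-c4ccco4)c32)cc1`: 94.5 nM
- compound 2 `COc1ccc(S(=O)(=O)N2CCc3cccc(-c4ccc([N+](=O)[O-])cc4)c32)cc1`: 53.1 nM
- compound 3 `COc1ccc(S(=O)(=O)N2CCc3cccc(-c4ccncc4)c32)cc1`: 101 nM

Compound 3 stands level with the other two: a 1.1-fold higher number from compound 1 to compound 3 (0.03 log units; within the scatter) and a 1.9-fold higher number from compound 2 to compound 3 (0.28 log units; within the scatter). Compound 4 `COc1ccc(S(=O)(=O)N2CCc3cccc(-c4cccnc4)c32)cc1` has the same atoms as compound 3, joined differently: pyridin-3-yl in place of pyridin-4-yl on an aromatic carbon. Among the compounds with values here, no measured pair isolates this kind of change. The nearest guides are those two steps and a 1.8-fold lower number from compound 1 to compound 2 (0.25 log units; within the scatter). Each exchanges one group for another on the same aromatic carbon, and none leaves the scatter. The change in this assay is therefore expected to stay small. The expected step is a 1.2-fold lower number from compound 3 to compound 4 (0.07 log units; within the scatter), none beyond the scatter. Compound 4 is estimated at 85 nM, with an expected range of 40 nM to 180 nM.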

Compound 4, half-maximal inhibitory concentration: 89.6 nM
Estimate against measurement, compound 4: 1.1-fold (0.02 log units) below; low and high end bracket the measured number.
By their numbers in this assay, from the lowest: compounds 2, 4, 1 and 3 (each within the scatter of the next).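

Swapping pyridin-4-yl for pyridin-3-yl on this aromatic carbon, a change that keeps the same atoms and alters only how they are joined, leaves this assay essentially unmoved (a 1.1-fold lower number from compound 3 to compound 4 (0.05 log units; within the scatter)). The pyridin-3-yl group also stands level with the two other groups tried here (a 1.1-fold lower number from compound 1 to compound 4 (0.02 log units; within the scatter); a 1.7-fold higher number from compound 2 to compound 4 (0.23 log units; within the scatter)), so all four aromatic rings at this place remain within the scatter. No measurement at hand explains this flat result. On these data alone, whether pyridin-2-yl would also stay level remains open. So does the effect of a non-aromatic group here, such as an amine, a carboxylic acid or a longer chain.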